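A few compounds are considered here, and "the series" means these few. Any claim that something is new, unique, unknown or untested is made for them only; others in the source may bear on it.

Compound 1 `COc1ccc(S(=O)(=O)NCCCN2CCN(c3ccc(C(F)(F)F)cc3)CC2)cc1` gives 384 nM in an assay on CHO cells for displacement of a labelled ligand from 5-hydroxytryptamine receptor 7 (Homo sapiens); on this read-out lower numbers stand for stronger inhibition and higher numbers for weaker inhibition.
Compound 2 `COc1ccc(S(=O)(=O)NCCCN2CCN(c3ccccc3)CC2)cc1` gives > 10000 nM in this assay, which is a limit of the assay and not a number.

Compound 2 therefore stands at the limit of > 10000 nM in this assay, at which 1 of the 2 values shown sits, and only a limit is known for it. Compound 3 `COc1ccc(S(=O)(=O)NCCCN2CCN(c3ccc([N+](=O)[O-])cc3)CC2)cc1` differs from compound 2 by nitro in place of hydrogen on an aromatic carbon. For the measured compounds named here, the one measured step that bears on this ring carbon is an at least 26-fold higher number from compound 1 to compound 2 (1.41 log units; beyond the scatter), where trifluoromethyl gave way to hydrogen. The reverse move, hydrogen to a substituent, is expected to lower the number again, though nitro need not match trifluoromethyl. Compound 3 is expected near 1500 nM in this assay, between 300 nM and 10000 nM. This is an expected step of an at least 6.6-fold lower number from compound 2 to compound 3 (0.82 log units; beyond the scatter).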

Compound 3, half-maximal inhibitory concentration: > 10000 nM
Compound 3: only a limit was reported; the forecaster's own chance of this, stated with the estimate: 30%; middle value at least 6.6-fold (0.82 log units) from the limit.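

Nitro at this ring carbon does not stand in for trifluoromethyl in this assay: the exchange gives an at least 26-fold higher number from compound 1 to compound 3 (1.41 log units; beyond the scatter). A substituent on this carbon is therefore not enough by itself, and among the three compounds only trifluoromethyl gives a reading short of the limit. The step from compound 2 to compound 3 cannot be read, since both compounds sit at a limit of the assay and not at a number: the limit of > 10000 nM in this assay, at which 2 of the 3 values shown sit.

Going by these compounds, whether chlorine, a nitrile or an amine on this carbon would give a measurable value stays open. So does any difference between hydrogen and nitro beyond the limit.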